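Notes on a benzylamide series at the bile acid receptor

The compounds below may be only part of what the source reports. "The series", "measured", "known", "first", "only" and "open" are said of these compounds alone.

Measured compounds and values:
compound 1 `CC(C)(C)c1ccc(C(=O)NCc2ccc(C(N)=O)cc2)cc1` gives 3800 nM
compound 2 `CC(C)(C)c1ccc(C(=O)NCc2ccc(C(=O)O)cc2Cl)cc1` gives 7500 nM
compound 3 `O=C(O)c1ccc(CNC(=O)c2cccc(-c3ccccc3)c2)cc1` gives 670 nM

All three numbers come from an assay on HeLa cells with Bile acid receptor (Homo sapiens) as the target, read by a luciferase reporter, with a stated time of 24 h; on this read-out lower numbers stand for an effect already at smaller amounts and higher numbers for an effect only at larger amounts of compound. Compound 1 stands second highest of the three. Its nearest neighbour is compound 2, whose number is higher, but this gap lies within the scatter, so no order between compound 1 and compound 2 can be read. The furthest is compound 3, whose number is lower by a gap beyond the scatter; compound 3 differs from compound 1 in more than one place, so only the two values themselves can be compared.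

The next compound, compound 4 `CC(C)Oc1ccc(CNC(=O)c2ccc(C(C)(C)C)cc2)cc1`, is not yet measured in this assay. It differs from compound 1 in one place: isopropoxy in place of carbamoyl on an aromatic carbon. The group leaves from an aromatic carbon of a six-membered aromatic ring of carbon only, para to a large group.

Among the compounds with values here, no step between measured compounds shows this change, so nothing tells its direction. The expectation is a step of a 1.3-fold higher number from compound 1 to compound 4 (0.12 log units; within the scatter) of small size, most likely within the scatter, with the higher number slightly more probable than the lower. For compound 4 the estimate is 5000 nM, with a range from 1500 nM to 16000 nM.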

Compound 4, half-maximal effective concentration: 170 nM
Estimate against measurement, compound 4: 29-fold (1.47 log units) above, outside the stated range (below it).
By their numbers in this assay, from the lowest: compound 4; then compound 3; then compounds 1 and 2 (each within the scatter of the next).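

In this assay, isopropoxy in place of carbamoyl on an aromatic carbon, para to a large group, gives a 22-fold lower number from compound 1 to compound 4 (1.35 log units; beyond the scatter) as a large step beyond the scatter. Within the data shown here, this place on the shared core is therefore sensitive to the group it carries, which the earlier compounds could not show, since no step linked any two of them. Compound 4 also has no hydrogen-bond donor in this group, so a donor here is not required for a low number on this read-out, although a single pair cannot separate the loss of the donor from the other differences between the two groups. No measurement at hand bears on the reason for the step.

On these data alone, it remains open whether the ether oxygen or the branched alkyl part of isopropoxy carries the step, a question that a methoxy or a tert-butyl group at the same place would address. As far as these compounds go, it is also open whether an amine or a longer alkoxy chain here would stay near compound 4 or fall back towards compound 1.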